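Diethylaminomethyl Substitution on Two Chromone Scaffolds

A few compounds are considered here, and "the series" means these few. Any claim that something is new, unique, unknown or untested is made for them only; others in the source may bear on it.

Measured compounds:
Compound 1, `Cc1ccc2c(=O)cc(-c3ccccc3Cl)oc2c1`: 28300 nM
Compound 2, `CCN(CC)Cc1ccc2c(=O)cc(-c3ccccc3Cl)oc2c1`: 10700 nM
Compound 3, `Cc1cccc2c(=O)cc(-c3ccc([N+](=O)[O-])cc3)oc12`: "not determined" (no result reported)

In a functional assay on HepG2 cells (Homo sapiens) for cytotoxicity, read by MTT assay, with a stated time of 48 h (on this read-out lower numbers stand for stronger inhibition and higher numbers for weaker inhibition), compound 1 gives 28300 nM, while compound 2 gives 10700 nM. The change between them is diethylamino in place of hydrogen on a saturated chain carbon bound to an aromatic carbon, and it produced a 2.6-fold lower number from compound 1 to compound 2 (0.42 log units; beyond the scatter).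

Compound 3 shares this general layout but differs from compound 1 in more than one place; the difference between the two cores is not broken down here. In this assay compound 3 is reported as "not determined" (no result reported), so no number was obtained for it.

Compound 4, `CCN(CC)Cc1cccc2c(=O)cc(-c3ccc([N+](=O)[O-])cc3)oc12`, stands to compound 3 exactly as compound 2 stands to compound 1: the change is diethylamino in place of hydrogen on a saturated chain carbon bound to an aromatic carbon, at the same place as before, so it is the same change. Compound 3 lacks a value, so the expectation for compound 4 cannot be built as a step from its direct parent. Instead, compound 4 is expected to land near compound 2, because the step of a 2.6-fold lower number from compound 1 to compound 2 (0.42 log units; beyond the scatter) shows where this change carried the closest measured pair. The estimate for compound 4 in this assay is 12000 nM, within roughly 3500 nM to 40000 nM.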

Compound 4, half-maximal inhibitory concentration: 28800 nM
For compound 4 the middle estimate is 2.4-fold (0.38 log units) below the measured one, and the stated range covers the measured number.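

Going by these compounds alone, compound 3 has no number in this assay, so no step from it to compound 4 can be read. On these data alone, whether swapping hydrogen for diethylamino changes the number on the core of compound 3 as it did on the core of compound 1 stays open. Nothing shown here offers an explanation for the value of compound 4.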